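The compounds below may be only part of what the source reports. "The series", "measured", "known", "first", "only" and "open" are said of these compounds alone.

Working notes on the series. The shared core carries a benzyl group on the pyrazole nitrogen; compound 1 `CCCn1c(=O)c2nc(-c3cnn(Cc4cccc(C)c4)c3)[nH]c2n(CCC)c1=O` has a 3-methylbenzyl, compound 3 `CCCn1c(=O)c2nc(-c3cnn(Cc4cccc(Cl)c4)c3)[nH]c2n(CCC)c1=O` a 3-chlorobenzyl, and compound 2 `CCCn1c(=O)c2nc(-c3cnn(Cc4ccc(F)cc4F)c3)[nH]c2n(CCC)c1=O` a 2,4-difluorobenzyl. In an assay on CHO cells for displacement of a labelled ligand from adenosine receptor A1 (Homo sapiens) (a lower number here means a stronger inhibitor, a higher number a weaker inhibitor), compound 1 gives 48 nM and compound 3 gives 31 nM; for compound 2 the entry reads "not determined" (no result reported), so no number is reported for it. Going by the values given here, compound 3 has the lowest of the two numbers, but the only step, a 1.5-fold lower number from compound 1 to compound 3 (0.19 log units; within the scatter), is within the scatter, so the two are not separated.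

Compound 4 `CCCn1c(=O)c2nc(-c3cnn(Cc4ccccc4OC)c3)[nH]c2n(CCC)c1=O` follows from compound 3 by 2-methoxyphenyl in place of 3-chlorophenyl on a saturated chain carbon bound to an aromatic nitrogen. Among the compounds with values here, the one measured step bears on it only loosely: it swapped one substituent for another at the same site and changed nothing beyond the scatter. Here both the group and its place on the ring change, and no measured pair speaks to a methoxy group or to the 2-position, so the expectation rests on the flat behaviour seen so far. In this assay compound 4 is expected to stay near compound 3, with a step of a 1.6-fold higher number from compound 3 to compound 4 (0.21 log units; within the scatter) and an estimate of 50 nM in the range 20 nM to 130 nM.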

Compound 4, inhibition constant: 59 nM
Beside the measured number, compound 4's estimate is 1.2-fold (0.07 log units) below it; low and high end bracket the measured number.
By their numbers in this assay, from the lowest: compounds 3, 1 and 4 (each within the scatter of the next).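

In this assay, the change to 2-methoxyphenyl on a saturated chain carbon bound to an aromatic nitrogen gives a 1.9-fold higher number from compound 3 to compound 4 (0.28 log units; within the scatter) and, starting from 3-methylphenyl, a 1.2-fold higher number from compound 1 to compound 4 (0.09 log units; within the scatter) and so separates compound 4 from neither neighbour. Unlike the earlier step, this change alters both the group and its place on the ring and brings in a hydrogen-bond acceptor, yet compound 1, compound 3 and compound 4 all remain within the scatter of one another. No supporting measurement bears on this flat result.

Still open, going by these compounds, is how 3-methoxyphenyl would compare with 2-methoxyphenyl, which would divide the contribution of the group from that of its place on the ring. Also open, on these data alone, is whether an amine, a carboxylic acid or a longer chain in place of the substituted phenyl would move the number beyond the scatter.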